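Swapping one substituted phenyl ring on a shared core

A few compounds are considered here, and "the series" means these few. Any claim that something is new, unique, unknown or untested is made for them only; others in the source may bear on it.

Compound 1 `CCOC(=O)C1=C(C)NC(C)=C(C(=O)OCC)C1c1c(-c2ccc(OC(F)(F)F)cc2)nc2sc(Br)cn12` was tested in an ADME assay on Left cardiac atrium (Cavia porcellus) (on this read-out lower numbers stand for an effect already at smaller amounts and higher numbers for an effect only at larger amounts of compound), and gives 93 nM. Going by the values given here, of the two compounds measured so far, compound 1 gives the higher number; compound 2 `CCOC(=O)C1=C(C)NC(C)=C(C(=O)OCC)C1c1c(-c2cc([N+](=O)[O-])c(Cl)cc2Cl)nc2sc(CC)cn12` gives 33 nM in this assay, and the gap between these two values lies beyond the usual scatter of repeated measurements. Compound 3 `CCOC(=O)C1=C(C)NC(C)=C(C(=O)OCC)C1c1c(-c2cc(OC)ccc2OC)nc2sc(Br)cn12` has not yet been measured. It differs from compound 1 in one place: 2,5-dimethoxyphenyl in place of 4-(trifluoromethoxy)phenyl on an aromatic carbon. Among the compounds with values here, compound 2 differs from compound 1 in more than one place, so no measured pair shows what this particular exchange does on its own, and the direction remains open. The expected step is a 1.1-fold higher number from compound 1 to compound 3 (0.03 log units; within the scatter), which lies within the scatter in either direction. For compound 3 the estimate in this assay is 100 nM, with a range from 30 nM to 400 nM.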

Compound 3, half-maximal effective concentration: 26 nM
The estimate for compound 3 lay 3.8-fold (0.59 log units) above the measured number; the whole stated range lies above it.
By their numbers in this assay, from the lowest: compounds 3 and 2 (each within the scatter of the next); then compound 1.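

Replacing the 4-(trifluoromethoxy)phenyl of compound 1 with 2,5-dimethoxyphenyl, with the rest of the molecule unchanged, gives a 3.6-fold lower number from compound 1 to compound 3 (0.55 log units; beyond the scatter) in this assay. Going by these compounds alone, this is the first comparison here between compounds that differ in one place only, and it shows that the group on this aromatic carbon can by itself shift the number beyond the usual scatter. Nothing available explains the shift, so it stands as an observation without a stated cause.

Going by these compounds, with a single exchange at this place, it stays open whether both methoxy groups are needed or whether one alone would give a similar number. Also open, on these data alone, is how this read-out would respond to an unsubstituted phenyl ring, to an amine or a carboxylic acid on that ring, or to a longer chain in place of a methoxy group.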